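From fluoro to cyclohexyl on a shared core

A few compounds are considered here, and "the series" means these few. Any claim that something is new, unique, unknown or untested is made for them only; others in the source may bear on it.

Within the data shown here, in a physicochemical assay for activation, with a stated time of 60 min (on this read-out higher numbers stand for an effect only at larger amounts of compound and lower numbers for an effect already at smaller amounts), compound 2 `O=C1NC(=O)/C(=C\c2ccc(F)cc2)C2=C1CCCC2` gives 60000 nM, the higher of the two numbers so far, while compound 1 `CCCCCc1ccc(/C=C2\C(=O)NC(=O)C3=C2CCCC3)cc1` gives 9200 nM. Compound 3 `O=C1NC(=O)/C(=C\c2ccc(C3CCCCC3)cc2)C2=C1CCCC2` carries cyclohexyl in place of fluoro on an aromatic carbon, para to a large group: cyclohexyl in place of fluoro on an aromatic carbon. Among the measured compounds shown here, one measured step bears on this change: fluoro in place of pentyl gave a 6.5-fold higher number from compound 1 to compound 2 (0.81 log units; beyond the scatter), a modest step beyond the scatter. Cyclohexyl, like the pentyl of compound 1, is carbon only, so a lower number of similar size is expected: a 5.0-fold lower number from compound 2 to compound 3 (0.70 log units; beyond the scatter). The estimate for compound 3 is 12000 nM, with an expected range of 4000 nM to 35000 nM.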

Compound 3, half-maximal effective concentration: 121000 nM
The estimate for compound 3 lay 10-fold (1.00 log units) below the measured number, and the stated range ends below it.
By their numbers in this assay, from the lowest: compound 1; then compounds 2 and 3 (each within the scatter of the next).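

In this assay the swap of fluoro for cyclohexyl gives a 2.0-fold higher number from compound 2 to compound 3 (0.30 log units; within the scatter) and leaves compound 2 and compound 3 impossible to tell apart. Being carbon only is therefore not enough to match pentyl on this aromatic carbon: the swap of pentyl for cyclohexyl gives a 13-fold higher number from compound 1 to compound 3 (1.12 log units; beyond the scatter) and sets compound 1 apart from the other two. Nothing measured here explains this gap. Still open, from the compounds shown here alone, is whether a shorter chain such as propyl would fall with compound 1 or with compound 2 and compound 3. The same question stands for an amine or a carboxylic acid at this place.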